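Azole Swap on the Shared Core and Metabolic Stability

The source may hold more compounds than are shown below. What is called first, only, known or untested is meant among the compounds shown, and "the series" means these compounds.

Measured compounds:
compound 1 `CNc1nc(NC2(C#N)CCCCC2)nc(-n2cccn2)n1` — 103 mL/min/kg
compound 2 `CCCC(C#N)(CC)Nc1nc(NC)nc(-n2cncn2)n1` — 29 mL/min/kg
compound 3 `CCC(C)(C#N)Nc1nc(NC)nc(-n2cncn2)n1` — 32 mL/min/kg

Three compounds have been run in an ADME assay on microsomes from liver (Rattus norvegicus) for metabolic stability; a lower number here means slower removal, a higher number faster removal of the compound. Compound 1 stands at the highest number of the three, at 103 mL/min/kg; the nearest is compound 3, whose value lies beyond the scatter below it, and compound 2 lies slightly further below still. Compounds 2 and 3 differ from each other only on a saturated chain carbon, and that step, a 1.1-fold higher number from compound 2 to compound 3 (0.04 log units; within the scatter), changes nothing beyond the scatter.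

The account now turns to compound 4 `CNc1nc(NC2(C#N)CCCCC2)nc(-n2cnc(C)n2)n1`, which is not yet measured. It differs from compound 1 at a single place: 3-methyl-1H-1,2,4-triazol-1-yl in place of 1H-pyrazol-1-yl on an aromatic carbon. Among the compounds with values here, no measured pair isolates this azole exchange. Within the data shown here, compounds 2 and 3 carry a triazolyl group on the shared core and both sit well below compound 1, but they also differ from compound 1 in the group attached to the nitrile-bearing carbon, so their values show only that the lower numbers coincide with the triazole-bearing compounds. Among the measured compounds shown here, the one measured step, from compound 2 to compound 3, concerns the chain and bears on the present change only indirectly.

Compound 4 is therefore expected to give 55 mL/min/kg, with a range from 25 mL/min/kg to 115 mL/min/kg. This estimate means an expected step of a 1.9-fold lower number from compound 1 to compound 4 (0.27 log units; within the scatter), downward, though with wide uncertainty.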

Compound 4, clearance: > 276 mL/min/kg
Compound 4: a limit, no number (the forecaster's own chance of this, stated with the estimate: 0%); at least 5.0-fold (0.70 log units) between middle value and limit.
By their numbers in this assay, from the lowest: compounds 2 and 3 (each within the scatter of the next); then compound 1. At a limit, above all of these: compound 4.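

Compound 4 reaches a limit of the assay rather than a number, so its result in this assay marks only where the reading stops: the limit of > 276 mL/min/kg in this assay, at which 1 of the 4 values shown sits.

Within the data shown here, this is the first direct reading of the azole at this position, on an aromatic carbon between two ring nitrogen atoms, and 3-methyl-1H-1,2,4-triazol-1-yl in place of 1H-pyrazol-1-yl gives an at least 2.6-fold higher number from compound 1 to compound 4 (0.42 log units; beyond the scatter), so the change moves the number upward by an amount beyond the scatter, with its full size unknown. The lower numbers of compounds 2 and 3 therefore cannot be credited to a triazolyl group as such, since a methyl-bearing triazolyl group on the core of compound 1, with its group at the nitrile-bearing carbon unchanged, goes the other way.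

The compounds shown do not separate the methyl group from the added ring nitrogen, and an unsubstituted 1H-1,2,4-triazol-1-yl group on the core of compound 1 would tell these two apart. They also leave open whether 3-methyl-1H-1,2,4-triazol-1-yl would give the same upward step on the open chains of compounds 2 and 3.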